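The source may hold more compounds than are shown below. What is called first, only, known or untested is meant among the compounds shown, and "the series" means these compounds.

Series notes. Compound 1 `C=CC1=C(C(=O)NCCCCC)C(c2ccc(OC)cc2)OC1` and compound 2 `C=CC1=C(C(=O)NCCC)C(c2ccc(OC)c(OC)c2)OC1` share the core; compound 3 `C=CC1=C(C(=O)NCCC)C(c2ccc(OC)cc2)OC1` is yet to be run. In a functional assay on HeLa cells (Homo sapiens) for cytotoxicity, read by MTT assay, with a stated time of 24 h (on this read-out lower numbers stand for stronger inhibition and higher numbers for weaker inhibition), compound 1 gives > 100000 nM, a limit of the assay rather than a number. In this assay compound 2 likewise gives > 100000 nM, again a limit. Compound 2 therefore stands at the limit of > 100000 nM in this assay, at which 2 of the 2 values shown sit, with no numbered value to anchor a step. Compound 3 differs from compound 2 by hydrogen in place of methoxy on an aromatic carbon. With both measured compounds at the limit, no step beyond the scatter is expected in this assay, and the step is estimated as a step that the limit leaves unreadable from compound 2 to compound 3. Compound 3 is expected near 150000 nM, between 50000 nM and 500000 nM, most likely reported only as a limit.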

Compound 3, half-maximal inhibitory concentration: 14000 nM
The estimate for compound 3 lay 11-fold (1.03 log units) above the measured number, and the stated range ends above it.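

In this assay hydrogen in place of methoxy, ortho to a methoxy group, gives an at least 7.1-fold lower number from compound 2 to compound 3 (0.85 log units; beyond the scatter) and so shows that this aromatic position can move the number. Hydrogen in place of ethyl on a saturated chain carbon, three bonds along the chain from an amide-type nitrogen, gives an at least 7.1-fold lower number from compound 1 to compound 3 (0.85 log units; beyond the scatter) and so shows that the amide chain can move it too. Both steps are minimum sizes, since each starts from a limit: the limit of > 100000 nM in this assay, at which 2 of the 3 values shown sit.

The compounds shown leave open whether a hydroxyl or an amine in place of the remaining methoxy keeps this activity. As far as these compounds go, a shorter amide chain such as methyl is also open.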